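Removing the Methyl from an Aryl Ether: Expected Cytotoxicity

A few compounds are considered here, and "the series" means these few. Any claim that something is new, unique, unknown or untested is made for them only; others in the source may bear on it.

Of the compounds shown here, two have so far been measured in a functional assay on LOX IMVI cells (Homo sapiens) for cytotoxicity, read by sulforhodamine B assay, with a stated time of 48 h, tested at 100 nM; a lower number here means a stronger effect, a higher number a weaker effect of the compound at the concentration tested. Compound 1 `COc1cc(C)cc(-c2c(-c3ccnc(-c4ccc(N(C)C)cc4)c3)cnn2CC#N)c1` gives 19% in this assay. Within the data shown here, compound 2 `COc1cc(C)cc(-c2nn(CC#N)cc2-c2ccnc(-c3ccc(N(C)C)cc3)c2)c1` gives 39% in this assay, the higher of the two numbers and hence the weaker effect at the concentration tested; its only neighbour, compound 1, lies lower by a margin beyond the usual scatter.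

Compound 3 `Cc1cc(O)cc(-c2nn(CC#N)cc2-c2ccnc(-c3ccc(N(C)C)cc3)c2)c1` has not yet been measured. It differs from compound 2 in one place: hydrogen in place of methyl on an oxygen on an aromatic ring, that is, methoxy becomes hydroxy and 3-methoxy-5-methylphenyl becomes 3-hydroxy-5-methylphenyl. Among the measured compounds shown here, no measured pair shows this change, so the data give no size for the step. The step from compound 2 to compound 3 in this assay is expected to be a number 1 percentage points higher from compound 2 to compound 3 (within the scatter), with no clear direction beyond the scatter. Compound 3 is therefore estimated to give 40%, within a range from 20% to 65%.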

Compound 3, a percentage reported as activity, at one concentration (the size of the read-out at that concentration, not a potency): 101%
Compound 3: the middle estimate sits 61 percentage points below what was measured, outside the stated range (above it).
By their numbers in this assay, from the lowest: compound 1; then compound 2; then compound 3.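

Going from methoxy to hydroxy on the 3-methoxy-5-methylphenyl group gives a number 62 percentage points higher from compound 2 to compound 3 (beyond the scatter) in this assay. Among these compounds, this is the first sign that this position is sensitive: the loss of a single carbon, the methyl on this oxygen, is enough to leave compound 3 at 101%, so at the concentration tested the effect seen with compound 2 depends on that methyl being present. Nothing measured here accounts for the size of this step.

The compounds shown leave open whether a longer chain on this oxygen, such as ethoxy, or an amine in place of the hydroxy would restore the effect. They also leave open whether the same change would give a step of similar size on the core of compound 1.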